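Swapping a Benzyl Hydrogen for Methylsulfanyl

The source may report more compounds than this note shows. Statements on the series, on what has been measured and on what is new or still open speak of the compounds shown alone.

Measured so far:
compound 1, `CCCCC[Se]c1nc(NCc2ccc(SC)cc2)c2ccccc2n1`, 65000 nM
compound 2, `C[Se]c1nc(NCc2ccccc2)c2ccccc2n1`, 67000 nM

Both compounds were tested in a functional assay on MCF7 cells (Homo sapiens) for cytotoxicity, read by MTT assay, with a stated time of 72 h; a lower number here means a stronger inhibitor of growth, a higher number a weaker inhibitor of growth. Compound 2 gives 67000 nM there, and compound 1 gives 65000 nM; these two numbers lie within the usual scatter of each other, so neither can be told apart from the other on this evidence. Compound 3, `CSc1ccc(CNc2nc([Se]C)nc3ccccc23)cc1`, has not yet been measured. It is made from compound 2 by one change: methylsulfanyl in place of hydrogen on an aromatic carbon. Going by the values given here, no step of this kind between two measured compounds exists, so there is no direct precedent to lean on. Since compound 1, which also carries a methylsulfanyl group on that ring, sits at 65000 nM, the change is expected to leave this assay essentially unmoved, with the step from compound 2 to compound 3 expected to be a 1.1-fold lower number from compound 2 to compound 3 (0.03 log units; within the scatter), no larger than the scatter. Compound 3 is therefore estimated at 62000 nM, with a likely range from 30000 nM to 130000 nM.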

Compound 3, concentration for total growth inhibition: > 100000 nM
Compound 3 was reported as a limit; the forecaster's own chance of this, stated with the estimate: 15%; middle value at least 1.6-fold (0.20 log units) away from the limit.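

In this assay compound 3 gives > 100000 nM, which is a limit of the assay and not a number. Methylsulfanyl in place of hydrogen on the aromatic carbon para to a large group therefore comes out as an at least 1.4-fold higher number from compound 2 to compound 3 (0.17 log units; that floor lies within the scatter), and hydrogen in place of butyl on the chain carbon bound to selenium comes out as an at least 1.5-fold higher number from compound 1 to compound 3 (0.18 log units; that floor lies within the scatter). These floors show no real change, but with a methyl chain on selenium the new group brings no measurable gain in growth inhibition, and the true size of both steps cannot be read past the top of the assay: the limit of > 100000 nM in this assay, at which 1 of the 3 values shown sits.

On these data alone, whether a methoxy group or an amine at this ring position would give a lower number stays open. So does how the longer chain on selenium behaves with hydrogen at this position.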